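Bromo to methoxy in a weak growth inhibitor

The source may report more compounds than this note shows. Statements on the series, on what has been measured and on what is new or still open speak of the compounds shown alone.

Compound 1 `CCOC(=O)c1nn(-c2ccc(Cl)cc2)c(-c2ccc(OC)cc2)c1CNC(C)(C)C` gives 60100 nM; > 523000 nM (2 entries)
Compound 2 `CC(C)(C)NCc1c(C(=O)O)nn(-c2ccccc2)c1-c1ccc(Br)cc1` gives 366000 nM
Compound 3 `CC(C)(C)NCc1c(C(=O)O)nn(-c2ccc(Cl)cc2)c1-c1ccc(Br)cc1` gives > 542000 nM
Compound 4 `COc1ccc(-c2c(CNC(C)(C)C)c(C(=O)O)nn2-c2ccc(Cl)cc2)cc1` is not yet measured

In an ADME assay on HaCaT cells (Homo sapiens) for inhibition, read by sulforhodamine B assay, with a stated time of 48 h (a lower number here means a stronger inhibitor of growth, a higher number a weaker inhibitor of growth), compound 3 gives only a limit (> 542000 nM), not a number.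

The change to compound 4 is methoxy in place of bromo on an aromatic carbon, para to a large group (methoxy in place of bromo on an aromatic carbon). Among the compounds with values here, no measured step makes this same change. The nearest evidence is a different swap, chloro in place of hydrogen on an aromatic carbon, which gave an at least 1.4-fold higher number from compound 2 to compound 3 (0.17 log units; that floor lies within the scatter) and so shows no change beyond the scatter.

Compound 1 also carries the 4-methoxyphenyl group. Its entries are the several entries of compound 1 in this assay, 60100 nM; > 523000 nM (2 entries), one a number and the other a limit, so they offer only a loose guide.

Compound 4 is therefore expected to remain a weak inhibitor of growth, in the range of compound 2 (366000 nM). The expected change is an at least 1.2-fold lower number from compound 3 to compound 4 (0.08 log units; that floor lies within the scatter), which means no estimated shift beyond the scatter in either direction. For compound 4 the estimate is 450000 nM, with an expected range of 150000 nM to 650000 nM.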

Compound 4, concentration for 50% growth inhibition: 121000 nM
Estimate against measurement, compound 4: 3.7-fold (0.57 log units) above; measured number below the stated range.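

In this assay, replacing the 4-bromophenyl group with 4-methoxyphenyl gives an at least 4.4-fold lower number from compound 3 to compound 4 (0.65 log units; beyond the scatter), so a change at this place on the aromatic ring can move the growth-inhibition read-out by more than the usual scatter. Going by these compounds, compound 3 is recorded only as a limit, > 542000 nM, so this step is a minimum and the true size of the change remains unknown. Within the data shown here, the only earlier step, a chloro in place of a hydrogen on an aromatic carbon, gave an at least 1.4-fold higher number from compound 2 to compound 3 (0.17 log units; that floor lies within the scatter), so the methoxy swap provides the first step here that clearly exceeds the scatter.

The compounds shown compare only bromo and methoxy at this place, leaving open how a hydroxyl, an amine or a longer chain such as ethoxy would read there. It also remains unclear whether the methoxy group has the same effect with an ethyl ester in place of the carboxylic acid, as compound 1 has that ester and its entries do not agree: the several entries of compound 1 in this assay, 60100 nM; > 523000 nM (2 entries)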